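This account rests on a few compounds, and the source may have more. Where it says the series, first, only, none or still open, it means among the compounds named here.

Measured compounds:
Compound 1 `COc1cc(OC)cc(-c2cccc(NC(=O)CCc3ccc4c(c3)B(O)OC4)c2)c1` gives 21000 nM in a functional assay on MDA-MB-231 cells (Homo sapiens) for antiproliferative activity, read by MTT assay, with a stated time of 72 h; a lower number here means a stronger inhibitor, a higher number a weaker inhibitor.
Compound 2 `CC(=O)c1ccc(-c2cccc(NC(=O)CCc3ccc4c(c3)B(O)OC4)c2)cc1` gives 59000 nM in this assay.
Compound 3 `COc1cc(OC)cc(-c2cccc(NC(=O)CCc3cccc4c3COB4O)c2)c1` gives 93000 nM in this assay.

All three share a chain ending in an amide, and they differ in two places. Between compound 1 and compound 2 the change is 4-acetylphenyl in place of 3,5-dimethoxyphenyl on an aromatic carbon, and it gave a 2.8-fold higher number from compound 1 to compound 2 (0.45 log units; beyond the scatter). Between compound 1 and compound 3 the two cores differ by a group of 10 heavy atoms (7 carbon, 1 boron, 2 oxygen; one five-membered non-aromatic ring with 2 hetero atoms, one six-membered aromatic ring of carbon only) in place of a group of 10 heavy atoms (7 carbon, 1 boron, 2 oxygen; one five-membered non-aromatic ring with 2 hetero atoms, one six-membered aromatic ring of carbon only), on a saturated chain carbon, two bonds along the chain from a carbonyl carbon, which gave a 4.4-fold higher number from compound 1 to compound 3 (0.65 log units; beyond the scatter). Compound 3 has the highest number of the three, though its gap to compound 2 is within the scatter, so no order between those two can be claimed.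

Compound 4 `CC(=O)c1ccc(-c2cccc(NC(=O)CCc3cccc4c3COB4O)c2)cc1` has not been measured in this assay. Within the data shown here, it differs from compound 3 by 4-acetylphenyl in place of 3,5-dimethoxyphenyl on an aromatic carbon, and this is the same change as the one from compound 1 to compound 2, made at the same place. If the change carries over onto the core of compound 3, a step of similar size is expected in this assay. The measured step was a 2.8-fold higher number from compound 1 to compound 2 (0.45 log units; beyond the scatter). The estimated step is a 2.7-fold higher number from compound 3 to compound 4 (0.43 log units; beyond the scatter). This rests on a single measured pair, so the range is wide. Compound 4 is therefore expected to give about 250000 nM in this assay, with a likely range from 100000 nM to 600000 nM.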

Compound 4, half-maximal inhibitory concentration: 41000 nM
Compound 4: the middle estimate sits 6.1-fold (0.79 log units) above what was measured; measured number outside the range, below it.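

In this assay, the swap of 3,5-dimethoxyphenyl for 4-acetylphenyl did not carry over from one core to the other, and on the core of compound 3 it gave a 2.3-fold lower number from compound 3 to compound 4 (0.36 log units; beyond the scatter), which runs the opposite way to the step on the core of compound 1: the same change on two cores in this assay, a 2.8-fold higher number (0.45 log units; beyond the scatter) from compound 1 to compound 2 and a 2.3-fold lower number (0.36 log units; beyond the scatter) from compound 3 to compound 4, 6.4-fold (0.80 log units) apart, beyond the scatter of two such steps The change of core likewise depended on which of the two groups was present, and with 4-acetylphenyl it gave a 1.4-fold lower number from compound 2 to compound 4 (0.16 log units; within the scatter), which leaves no order between those two compounds, unlike the clear step seen with 3,5-dimethoxyphenyl: the same change on two cores in this assay, a 4.4-fold higher number (0.65 log units; beyond the scatter) from compound 1 to compound 3 and a 1.4-fold lower number (0.16 log units; within the scatter) from compound 2 to compound 4, 6.4-fold (0.80 log units) apart, beyond the scatter of two such steps Across these four compounds, then, the effects of the two changes cannot simply be added together, but the data do not show why the two changes depend on each other, and each step rests on a single pair of compounds.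

The compounds shown leave open whether the same dependence would appear with other groups on that aromatic ring, such as an amine or a carboxylic acid in place of the acetyl group. They also leave open whether it would persist with a longer chain in place of the present one.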